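Swapping the aryl substituent on a shared core

This account rests on a few compounds, and the source may have more. Where it says the series, first, only, none or still open, it means among the compounds named here.

Three measured compounds share one core and differ only in the substituent on the phenyl ring. In a functional assay on MCF7 cells (Homo sapiens) for antiproliferative activity, read by sulforhodamine B assay, with a stated time of 48 h (on this read-out lower numbers stand for stronger inhibition of growth and higher numbers for weaker inhibition of growth), compound 1 `Cc1ccc(-c2cc(N3CCC(CNS(N)(=O)=O)CC3)ncn2)cc1` gives 30600 nM, compound 2 `COc1ccc(-c2cc(N3CCC(CNS(N)(=O)=O)CC3)ncn2)cc1` gives 35300 nM and compound 3 `NS(=O)(=O)NCC1CCN(c2cc(-c3ccc(C(F)(F)F)cc3)ncn2)CC1` gives 22500 nM. Compound 2 has the highest number of the three, yet every gap to it lies within the scatter: a 1.2-fold higher number from compound 1 to compound 2 (0.06 log units; within the scatter) and a 1.6-fold lower number from compound 2 to compound 3 (0.20 log units; within the scatter), while a 1.4-fold lower number from compound 1 to compound 3 (0.13 log units; within the scatter). Compound 4 `NS(=O)(=O)NCC1CCN(c2cc(-c3cccc(Cl)c3)ncn2)CC1` carries 3-chlorophenyl in place of 4-methoxyphenyl on an aromatic carbon. Going by the values given here, none of the measured steps moves the substituent to a different position, so they bear on this change only loosely, and all three stayed within the scatter. The step is therefore expected to be small, a 1.3-fold lower number from compound 2 to compound 4 (0.10 log units; within the scatter). Compound 4 is expected to give 28000 nM, within 12000 nM to 60000 nM, in this assay.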

Compound 4, concentration for 50% growth inhibition: 47100 nM
Beside the measured number, compound 4's estimate is 1.7-fold (0.23 log units) below it; low and high end bracket the measured number.
By their numbers in this assay, from the lowest: compounds 3, 1, 2 and 4 (each within the scatter of the next, the first and the last beyond it).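

In this assay the change from 4-methoxyphenyl to 3-chlorophenyl, the first here that also alters where the substituent sits on the phenyl ring, gives a 1.3-fold higher number from compound 2 to compound 4 (0.13 log units; within the scatter) and the change from 4-methylphenyl to 3-chlorophenyl gives a 1.5-fold higher number from compound 1 to compound 4 (0.19 log units; within the scatter) with both steps within the scatter. Even a change of substituent and its place together thus leaves no measurable difference between these pairs. No evidence is at hand that bears on this result.

With 4-chlorophenyl absent from the compounds shown, the effects of the chlorine and of its place stay unseparated. On these data alone, whether an amine or a carboxylic acid on the phenyl ring would give a step beyond the scatter also remains open.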